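Swapping a small amine for an isopropoxypiperidine on the core

This account rests on a few compounds, and the source may have more. Where it says the series, first, only, none or still open, it means among the compounds named here.

Compound 1 `CC(C(=O)NCc1ccc(C(F)(F)F)nc1Nc1ccccc1)c1ccc(NS(C)(=O)=O)c(F)c1`: 59.6 nM
Compound 2 `CC(C(=O)NCc1ccc(C(F)(F)F)nc1N(C)C)c1ccc(NS(C)(=O)=O)c(F)c1`: 19.1 nM

Both compounds were measured in a functional assay on CHO-K1 cells for antagonist activity at transient receptor potential cation channel subfamily V member 1 (Homo sapiens), read by FLIPR; on this read-out lower numbers stand for stronger inhibition and higher numbers for weaker inhibition. Compound 2 gives the lower of the two numbers: the step of a 3.1-fold lower number from compound 1 to compound 2 (0.49 log units; beyond the scatter) lies beyond the usual scatter, so compound 2 is the stronger inhibitor of this pair.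

Compound 3 `CC(C)OC1CCN(c2nc(C(F)(F)F)ccc2CNC(=O)C(C)c2ccc(NS(C)(=O)=O)c(F)c2)CC1` keeps everything of compound 2 except one place on the aromatic ring: 4-isopropoxypiperidin-1-yl in place of dimethylamino on an aromatic carbon. Among the measured compounds shown here, the only measured step that bears on this is the one from compound 1 to compound 2, where a smaller group at the same place gave the lower number. The new group is much larger again, but it is a saturated ring rather than an anilino group, so that step is an uncertain guide. The expected change in this assay is a mild move toward a higher number, possibly within the scatter. On that basis compound 3 is estimated at 30 nM, with a range from 8 nM to 110 nM, which means an expected step of a 1.6-fold higher number from compound 2 to compound 3 (0.20 log units; within the scatter).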

Compound 3, inhibition constant: 3 nM
Compound 3: the middle estimate sits 10-fold (1.00 log units) above what was measured, and the stated range ends above it.
By their numbers in this assay, from the lowest: compound 3; then compound 2; then compound 1.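

In this assay the change to 4-isopropoxypiperidin-1-yl gives a 6.4-fold lower number from compound 2 to compound 3 (0.80 log units; beyond the scatter) and so shows that this place on the ring, next to the ring nitrogen, accepts a far larger group than dimethylamino, with 10 heavy atoms entering where 3 leave, and still gains in inhibition. Measured against the anilino group, the same new group gives a 20-fold lower number from compound 1 to compound 3 (1.30 log units; beyond the scatter) and makes it the best of the three groups seen here, so the earlier hint that a smaller group gives the lower number does not hold as a general rule, and compound 3 is the compound that goes against it. The data shown offer nothing that explains why this saturated ring with its ether side group does so well.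

What the three compounds cannot separate is the share of the piperidine ring from the share of the isopropoxy group, and a plain piperidine or a 4-methoxypiperidine at the same place would pull those two apart. A morpholine or a 4-hydroxypiperidine would further test whether the oxygen needs to sit where it does, or needs the isopropyl carbons attached to it.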